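From carbamoyl to hydroxymethyl on a saturated ring carbon

A few compounds are considered here, and "the series" means these few. Any claim that something is new, unique, unknown or untested is made for them only; others in the source may bear on it.

In an in vivo ADME assay on the whole organism (strain Sprague-Dawley) for pharmacokinetics, with Rattus norvegicus as the target (a lower number here means that a smaller share of the oral dose reaches the circulation, a higher number that a larger share of the oral dose reaches the circulation), compound 1 `COc1cc(C(=O)N2[C@@H](c3nccs3)[C@@H](C(N)=O)C[C@@]2(CC(C)C)C(=O)O)ccc1C(C)(C)C` gives 0.6%, and compound 2 `CC(C)C[C@@]1(C(=O)O)C[C@H](C(N)=O)[C@H](c2nccs2)N1C(=O)c1ccc(C(C)(C)C)c(Br)c1` gives 2%. Within the data shown here, these two numbers lie within the scatter of each other, so compound 1 stands level with the only other compound measured. Compound 3 `COc1cc(C(=O)N2[C@@H](c3nccs3)[C@@H](CO)C[C@@]2(CC(C)C)C(=O)O)ccc1C(C)(C)C` keeps the core of compound 1 and differs in one place: hydroxymethyl in place of carbamoyl on a saturated ring carbon.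

Among the measured compounds shown here, only one measured step offers any guidance, and it is indirect: bromo in place of methoxy on an aromatic carbon, a number 1.4 percentage points higher from compound 1 to compound 2 (within the scatter). For the measured compounds named here, that swap lies elsewhere in the molecule, and no measurement yet tests a change at the carbamoyl group. On this thin evidence, no step beyond the scatter is expected in this assay, with an estimated a number 2.4 percentage points higher from compound 1 to compound 3 (within the scatter). For compound 3 the expected value is 3%, with an estimated range from 0.5% to 15%.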

Compound 3, oral bioavailability: 12%
Estimate against measurement, compound 3: 9 percentage points below; the measured number falls inside the stated range.
By their numbers in this assay, from the lowest: compounds 1, 2 and 3 (each within the scatter of the next, the first and the last beyond it).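

In this assay, the saturated ring carbon that bears the carbamoyl group proves to be a place where a single change can matter: hydroxymethyl in place of carbamoyl gives a number 11.4 percentage points higher from compound 1 to compound 3 (beyond the scatter), whereas the bromo-for-methoxy swap on the aromatic carbon stayed at a number 1.4 percentage points higher from compound 1 to compound 2 (within the scatter). The two groups have the same counts, 1 hydrogen-bond donor and 1 hydrogen-bond acceptor, with no net charge, so those counts do not distinguish them. No measurement available here explains the step.

On these data alone, it remains open whether the same step would appear with the bromo group of compound 2 in place of the methoxy group. Also open, as far as these compounds go, is how an aminomethyl group, a carboxylic acid or a longer chain such as 2-hydroxyethyl would compare on this ring carbon.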